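Shifting the benzyl substituent on a thio-linked purine nucleoside

The source may report more compounds than this note shows. Statements on the series, on what has been measured and on what is new or still open speak of the compounds shown alone.

Measured compounds:
compound 1, `N#Cc1cccc(CSc2ncnc3c2ncn3[C@@H]2O[C@H](CO)[C@@H](O)[C@H]2O)c1`: 36.3 nM
compound 2, `N#Cc1ccc(CSc2ncnc3c2ncn3[C@@H]2O[C@H](CO)[C@@H](O)[C@H]2O)cc1`: 4.57 nM
compound 3, `O=[N+]([O-])c1ccccc1CSc1ncnc2c1ncn2[C@@H]1O[C@H](CO)[C@@H](O)[C@H]1O`: 115 nM

The three compounds share one core and differ only in the aryl group carried on a saturated chain carbon bound to a sulfur. In an assay on isolated protein for inhibition of Equilibrative nucleoside transporter 1 (Homo sapiens) (on this read-out lower numbers stand for stronger inhibition and higher numbers for weaker inhibition), compound 2 gives the lowest number, and the step of a 7.9-fold lower number from compound 1 to compound 2 (0.90 log units; beyond the scatter) shows how far compound 2 sits from compound 1. Compound 3 stands highest of the three: the step of a 3.2-fold higher number from compound 1 to compound 3 (0.50 log units; beyond the scatter) separates it from its nearest neighbour, and the step of a 25-fold higher number from compound 2 to compound 3 (1.40 log units; beyond the scatter) from the furthest.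

Compound 4, `OC[C@H]1O[C@@H](n2cnc3c(SCc4cccc(C(F)(F)F)c4)ncnc32)[C@H](O)[C@@H]1O`, has not yet been measured in this assay. It differs from compound 3 in one place: 3-(trifluoromethyl)phenyl in place of 2-nitrophenyl on a saturated chain carbon bound to a sulfur. Both steps ending at compound 3 bear on this change, since each replaced a cyanophenyl by the 2-nitrophenyl and raised the number, modestly in the case of compound 1 and largely in the case of compound 2. Compound 4 carries its substituent on the same ring position as compound 1, so the step of a 3.2-fold higher number from compound 1 to compound 3 (0.50 log units; beyond the scatter) is the closer guide, and a reversal of roughly that size is expected. Compound 4 is therefore estimated at 30 nM, within 8 nM to 120 nM, which would mean a step of a 3.8-fold lower number from compound 3 to compound 4 (0.58 log units; beyond the scatter) expected from compound 3 to compound 4.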

Compound 4, inhibition constant: 19.1 nM
Beside the measured number, compound 4's estimate is 1.6-fold (0.20 log units) above it, and the stated range covers the measured number.
By their numbers in this assay, from the lowest: compound 2; then compounds 4 and 1 (each within the scatter of the next); then compound 3.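

In this assay, among the compounds shown here, the step of a 1.9-fold lower number from compound 1 to compound 4 (0.28 log units; within the scatter) shows that the 3-cyanophenyl and 3-(trifluoromethyl)phenyl groups cannot be told apart on a saturated chain carbon bound to a sulfur, a like-for-like comparison of two substituents that the earlier compounds did not offer. The step of a 6.0-fold lower number from compound 3 to compound 4 (0.78 log units; beyond the scatter) adds a second group that gives a lower number than 2-nitrophenyl, while the step of a 4.2-fold higher number from compound 2 to compound 4 (0.62 log units; beyond the scatter) shows that the trifluoromethyl compound does not reach the number of the 4-cyanophenyl compound, which stays lowest of the four with all its steps beyond the scatter. No measurement beyond these numbers is available to account for the differences among the four aryl groups.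

On these data alone, it remains open whether 4-(trifluoromethyl)phenyl would repeat the drop seen between the 3-cyanophenyl and 4-cyanophenyl groups, and whether 3-nitrophenyl or 4-nitrophenyl would separate the effect of the nitro group from that of its place on the ring. The compounds shown also leave open how an amine or a carboxylic acid on the aryl ring would read in this assay.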